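Methyl for Methoxy: Estimating Compound 4

The compounds below may be only part of what the source reports. "The series", "measured", "known", "first", "only" and "open" are said of these compounds alone.

Measured so far:
compound 1 `COc1ccc(Cn2c(O)nc3c(N)ncnc32)cc1` — 10 uM
compound 2 `CCc1nc(N)c2nc(O)n(Cc3ccccc3)c2n1` — 1 uM
compound 3 `Cc1nc(N)c2nc(O)n(Cc3ccccc3)c2n1` — 1 uM

In a functional assay (spleen, spleen) for activation, with Mus musculus as the target (on this read-out lower numbers stand for an effect already at smaller amounts and higher numbers for an effect only at larger amounts of compound), compound 1 gives 10 uM, the highest number of the three. Compound 2 gives 1 uM and compound 3 gives 1 uM, both lower than compound 1 by a gap beyond the scatter; compound 2 and compound 3 differ from compound 1 in more than one place, so their gaps to it cannot be assigned to a single change. Among the compounds with values here, the only single-place step recorded is no change at the digits printed from compound 2 to compound 3 (within the scatter), which concerns the shared core, not the benzyl ring.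

Compound 4 `Cc1ccc(Cn2c(O)nc3c(N)ncnc32)cc1` arises from compound 1 by methyl in place of methoxy on an aromatic carbon. Within the data shown here, no measured step touches this part of the molecule, so nothing in the data argues for a shift in either direction. The expectation is therefore a step of no change at the digits printed from compound 1 to compound 4 (within the scatter), that is, no change beyond the scatter. Compound 4 is estimated at 10 uM in this assay, with a range from 3 uM to 30 uM, the width reflecting the absence of any directly relevant comparison.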

Compound 4, minimum effective concentration: 10 uM
For compound 4 middle estimate and measured number coincide at the digits printed; the measured number falls inside the stated range.
By their numbers in this assay, from the lowest: compounds 2 and 3 (each within the scatter of the next); then compounds 1 and 4 (each within the scatter of the next).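

In this assay, methyl in place of methoxy on an aromatic carbon gives no change at the digits printed from compound 1 to compound 4 (within the scatter). Within the data shown here, this is the first single-place reading at this position, since the only earlier step, no change at the digits printed from compound 2 to compound 3 (within the scatter), lies in a different part of the molecule and said nothing about the ring that carries the methoxy. It shows that, at this carbon para to a large group, the exchange removes an oxygen and the one hydrogen-bond acceptor counted for methoxy without moving the number beyond the scatter, and no supporting measurement is available to explain why the two groups read alike.

From the compounds shown here alone, whether this tolerance extends to other groups at the same carbon, such as an amine, a carboxylic acid or a longer chain, remains open. Also open, going by these compounds, are whether a plain hydrogen there would read like methyl and methoxy, and whether either group would behave in the same way on the core of compound 2.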